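Trimethoxyphenyl replaces the styryl group on the pyrazoline core

The source may hold more compounds than are shown below. What is called first, only, known or untested is meant among the compounds shown, and "the series" means these compounds.

Compound 2 `Cc1cc(O)c(C2=NN(c3ccc(S(N)(=O)=O)cc3)C(/C=C/c3ccccc3)C2)cc1Cl` shows the higher of the two numbers recorded so far in a functional assay on IGROV-1 cells (Homo sapiens) for antiproliferative activity, with a stated time of 48 h (on this read-out lower numbers stand for stronger inhibition of growth and higher numbers for weaker inhibition of growth), giving 4320 nM, while its nearest neighbour, compound 1 `Cc1cc(O)c(C2=NN(c3ccc(S(N)(=O)=O)cc3)C(c3ccccc3Cl)C2)cc1Cl`, gives 2580 nM, and the difference a 1.7-fold higher number from compound 1 to compound 2 (0.22 log units; within the scatter) stays within the scatter. Compound 3 `COc1ccc(C2CC(c3cc(Cl)c(C)cc3O)=NN2c2ccc(S(N)(=O)=O)cc2)c(OC)c1OC` has not yet been tested. The change from compound 2 to compound 3 is 2,3,4-trimethoxyphenyl in place of 2-phenylethenyl on a saturated ring carbon. Going by the values given here, only one measured step bears on this: the exchange of one aryl group for another at the same saturated ring carbon, a 1.7-fold higher number from compound 1 to compound 2 (0.22 log units; within the scatter), did not move the number beyond the scatter. On that basis the switch to the 2,3,4-trimethoxyphenyl group is expected to leave the number near where compound 2 stands, with no step beyond the scatter, so the expected step is a 1.4-fold lower number from compound 2 to compound 3 (0.16 log units; within the scatter). For compound 3 the estimated value in this assay is 3000 nM, with a range from 1000 nM to 9000 nM.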

Compound 3, concentration for 50% growth inhibition: 2230 nM
Compound 3: middle estimate off by 1.3-fold (0.13 log units), on the high side, and the stated range covers the measured number.
By their numbers in this assay, from the lowest: compounds 3, 1 and 2 (each within the scatter of the next).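

The new steps widen what this saturated ring carbon can carry without a clear shift in this assay. Both a 1.9-fold lower number from compound 2 to compound 3 (0.29 log units; within the scatter) and a 1.2-fold lower number from compound 1 to compound 3 (0.06 log units; within the scatter) leave the number within the scatter, even though the 2,3,4-trimethoxyphenyl group brings 12 heavy atoms in place of the 8 of 2-phenylethenyl, and 3 hydrogen-bond acceptors in place of 0. The three compounds therefore cannot be ranked by this group, and nothing at hand offers a reason for that.

From the compounds shown here alone, every group seen at this carbon so far carries a six-membered aromatic ring of carbon only, so it remains open whether an amine, a carboxylic acid or a plain alkyl chain there would give a step beyond the scatter. The compounds shown also leave open how far the number depends on the 4-sulfamoylphenyl group or the 5-chloro-2-hydroxy-4-methylphenyl group, since both stay the same throughout.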